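Swapping a dimethylpyridine for a methylthiazole on a thiourea

This account rests on a few compounds, and the source may have more. Where it says the series, first, only, none or still open, it means among the compounds named here.

Measured so far:
compound 1 `Cc1csc(N/C(S)=N/[C@@H](C)c2cccc3ccccc23)n1` gives 83200 nM
compound 2 `Cc1ccc(N/C(S)=N/[C@H](C)c2cccc3ccccc23)nc1` gives 5 nM
compound 3 `Cc1cc(C)nc(N/C(S)=N/[C@H](C)c2cccc3ccccc23)c1` gives > 100000 nM

All three were tested in a functional assay on RBL-2H3 cells (Rattus norvegicus) for inhibition; on this read-out higher numbers stand for weaker inhibition and lower numbers for stronger inhibition. Compound 2 gives 5 nM in this assay. For compound 3 the result of > 100000 nM is a limit of the assay, not a number, so compound 3 stands only at the weak end of what this assay can report. For the measured compounds named here, the one measured step that leads there, an at least 20000-fold higher number from compound 2 to compound 3 (4.30 log units; beyond the scatter), shows how much was lost on that change; the reading the limit of > 100000 nM in this assay, at which 1 of the 3 values shown sits, marks where compound 3 sits.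

The unmeasured compound 4 `Cc1csc(N/C(S)=N/[C@H](C)c2cccc3ccccc23)n1` differs from compound 3 by 4-methyl-1,3-thiazol-2-yl in place of 4,6-dimethylpyridin-2-yl on an amine nitrogen. Going by the values given here, no measured step covers this exact change. Compound 1 carries the same 4-methyl-1,3-thiazol-2-yl group as compound 4 but differs in the spatial arrangement at its stereocentre, and compound 1 gives 83200 nM, a weak result, though still a number rather than a limit.

Since compound 3 already sits at a limit, the step is expected to go downward, to a stronger number: an at least 33-fold lower number from compound 3 to compound 4 (1.52 log units; beyond the scatter). Compound 4 is therefore estimated at 3000 nM, with a range from 50 nM to 100000 nM.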

Compound 4, half-maximal inhibitory concentration: 25900 nM
Estimate against measurement, compound 4: 8.6-fold (0.94 log units) below, within the range that was stated.
By their numbers in this assay, from the lowest: compound 2; then compound 4; then compound 1. At a limit, above all of these: compound 3.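

In this assay, putting the 4-methyl-1,3-thiazol-2-yl group on the amine nitrogen in place of the 4,6-dimethylpyridin-2-yl group gives an at least 3.8-fold lower number from compound 3 to compound 4 (0.58 log units; beyond the scatter), and this size is only a minimum, since compound 3 stands at a limit rather than at a number: the limit of > 100000 nM in this assay, at which 1 of the 4 values shown sits. That gain is small beside the cost of using the same group in place of the 5-methylpyridin-2-yl group, a 5200-fold higher number from compound 2 to compound 4 (3.71 log units; beyond the scatter), so at this place the choice of ring separates strong inhibition from very weak inhibition, and a five-membered ring with a methyl group does not restore what compound 2 achieves. The stereocentre matters far less here, with a 3.2-fold lower number from compound 1 to compound 4 (0.51 log units; beyond the scatter), and this modest gap can be assigned to the stereocentre alone, the basis being: the fact that compounds 1 and 4 differ only in the configuration as drawn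

As far as these compounds go, how much the stereocentre counts when the 5-methylpyridin-2-yl group is present remains open, since the comparison of mirror-drawn forms covers only the 4-methyl-1,3-thiazol-2-yl pair. Also open, from the compounds shown here alone, is how an unsubstituted pyridin-2-yl group or a plain phenyl ring would behave on the same amine nitrogen, and so whether the methyl group or the ring itself sets the result.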